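Two Measured Compounds and One Expected Value

The source may report more compounds than this note shows. Statements on the series, on what has been measured and on what is new or still open speak of the compounds shown alone.

Compound 2, `Cc1cc(N2CC[C@@H](C)[C@@H](N(C)c3ncnc4[nH]ccc34)C2)n2nc(SCc3cc(Cl)ccc3Cl)nc2n1`: 87500 nM
Compound 1, `CCc1cc(N2CC[C@@H](C)[C@@H](N(C)c3ncnc4[nH]ccc34)C2)n2ncnc2n1`: a limit, > 100000 nM

Among the measured compounds shown here, in a toxicity assay on GES1 cells (Homo sapiens) for inhibition, read by MTT assay, with a stated time of 72 h (a higher number here means a weaker inhibitor, a lower number a stronger inhibitor), compound 2 gives 87500 nM, the only number measured here; compound 2 is a weak inhibitor. For compound 1 the assay reports a limit rather than a number, > 100000 nM. That is the limit of > 100000 nM in this assay, at which 1 of the 2 values shown sits.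

Compound 3, `Cc1cc(N2CC[C@@H](C)[C@@H](N(C)c3ncnc4[nH]ccc34)C2)n2nc(SCc3ccc([N+](=O)[O-])cc3)nc2n1`, differs from compound 2 in one place: 4-nitrophenyl in place of 2,5-dichlorophenyl on a saturated chain carbon bound to a sulfur. For the measured compounds named here, no step between measured compounds exists here, so this change has no measured precedent. Given compound 2 at 87500 nM, compound 3 is expected to land nearby, a step of a 1.0-fold higher number from compound 2 to compound 3 (0.01 log units; within the scatter) of no size beyond the scatter. The estimate for compound 3 is 90000 nM, from 40000 nM to 200000 nM.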

Compound 3, half-maximal inhibitory concentration: 36600 nM
For compound 3 the middle estimate is 2.5-fold (0.39 log units) above the measured one; the whole stated range lies above it.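

In this assay, swapping 4-nitrophenyl for 2,5-dichlorophenyl on a saturated chain carbon bound to a sulfur gives a 2.4-fold lower number from compound 2 to compound 3 (0.38 log units; beyond the scatter), a modest shift towards stronger inhibition. Among the compounds shown here, this first measured step shows that the ring at this place can change the reading, which the earlier compounds could not show. Nothing measured here explains why the number moved.

Going by these compounds, the change removes both chlorines and adds the nitro group at once, so it remains open which part carries the step. A 4-chlorophenyl or 4-aminophenyl ring at the same place would help to separate them.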